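A Fluorine Added to Compound 3: What to Expect

The compounds below may be only part of what the source reports. "The series", "measured", "known", "first", "only" and "open" are said of these compounds alone.

Measured in a functional assay on MCF7 cells (Homo sapiens) for cytotoxicity, read by MTT assay, with a stated time of 72 h, tested at 10 uM; a higher number here means more inhibition of growth at the concentration tested, a lower number less inhibition of growth:
compound 1, `N/C(=N\NC(=S)N1CCCC1)c1ccc(F)cn1`, gives 54.5%
compound 2, `Cc1ccnc(/C(N)=N/NC(=S)N2CCSCC2)c1`, gives 62.5%
compound 3, `N/C(=N\NC(=S)N1CCSCC1)c1ccccn1`, gives 54.3%

Compound 3 stands lowest of the three numbers, with compound 1 nearest and compound 2 furthest, but both gaps lie within the scatter, so the three numbers cannot be told apart. Among the compounds with values here, the one step between measured compounds that differ in a single place, a number 8.2 percentage points lower from compound 2 to compound 3 (within the scatter), also stays within the scatter.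

Compound 4, `N/C(=N\NC(=S)N1CCSCC1)c1ccc(F)cn1`, differs from compound 3 by one change: fluoro in place of hydrogen on an aromatic carbon. Within the data shown here, compound 1 carries the same fluoro, though the rest of its structure differs in a second place, so no single step links it to compound 3; its number simply sits beside that of compound 3. Among the measured compounds shown here, the only measured step, the loss of a methyl on an aromatic carbon, moved the number little. On that basis the change from hydrogen to fluoro is expected to shift the result in this assay by no more than the scatter, in no particular direction. For compound 4 the estimate is 56%, between 44% and 68%, which means an expected step of a number 1.7 percentage points higher from compound 3 to compound 4 (within the scatter).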

Compound 4, percent growth inhibition at one concentration: 38.1%
Estimate against measurement, compound 4: 17.9 percentage points above; the measured number lies below the stated range.
By their numbers in this assay, from the lowest: compound 4; then compounds 3, 1 and 2 (each within the scatter of the next).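

In this assay a single fluoro on an aromatic carbon, two atoms from the ring nitrogen and para to a large group, gives a number 16.2 percentage points lower from compound 3 to compound 4 (beyond the scatter) and so shows that a change of one atom at this position can register clearly. Within the data shown here, the only earlier step, a number 8.2 percentage points lower from compound 2 to compound 3 (within the scatter) for the loss of a methyl, gave no such sign. Among these compounds, with the fluoro held in place, the group on the thiocarbonyl carbon proves to count as well, since thiomorpholin-4-yl in place of pyrrolidin-1-yl gives a number 16.4 percentage points lower from compound 1 to compound 4 (beyond the scatter) and no earlier step isolated that swap. No measurement offered here accounts for either step.

The compounds shown leave open whether fluoro in place of hydrogen would lower the number by a similar amount with pyrrolidin-1-yl on the thiocarbonyl carbon, or whether the drop belongs to the pairing with thiomorpholin-4-yl. They also leave open whether the drop is particular to fluorine or would also follow from a chlorine atom, a methoxy group or an amine at the same place on the ring.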